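The source may hold more compounds than are shown below. What is called first, only, known or untested is meant among the compounds shown, and "the series" means these compounds.

The measured compounds, in a functional assay on A549 cells (Homo sapiens) for inhibition, read by MTT assay; a lower number here means a stronger inhibitor, a higher number a weaker inhibitor:
compound 1, `CCCCCCCCn1cc(/C=C/C(=O)c2ccc(N)cc2)nn1`, gives 26900 nM;
compound 2, `CCCCCCCCn1cc(/C=C/C(=O)c2ccc(NC(=O)CN3CCN(C(=O)OC(C)(C)C)CC3)cc2)nn1`, gives 43300 nM;
compound 3, `CC(C)(C)OC(=O)N1CCN(CC(=O)Nc2ccc(C(=O)/C=C/c3cn(Cc4ccc(Br)cc4)nn3)cc2)CC1`, gives 38400 nM.

Compound 2 and compound 3 differ in one place only: 4-bromophenyl in place of heptyl on a saturated chain carbon bound to an aromatic nitrogen. That change made a step of a 1.1-fold lower number from compound 2 to compound 3 (0.05 log units; within the scatter). Compound 1 carries a different core from compound 2, and the difference between the two cores is not broken down here. All three values lie within the usual scatter of one another, so no order can be read among them.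

Compound 4, `Nc1ccc(C(=O)/C=C/c2cn(Cc3ccc(Br)cc3)nn2)cc1`, has not been measured. It differs from compound 1 by 4-bromophenyl in place of heptyl on a saturated chain carbon bound to an aromatic nitrogen, the same change that separates compound 2 from compound 3, at the same place. The expectation rests on the step of a 1.1-fold lower number from compound 2 to compound 3 (0.05 log units; within the scatter), which stayed within the scatter, so little movement is expected here too. The expected step is a 1.1-fold lower number from compound 1 to compound 4 (0.05 log units; within the scatter). Compound 4 is estimated at 24000 nM. Compound 4 is expected to fall between 10000 nM and 55000 nM.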

Compound 4, half-maximal inhibitory concentration: 15800 nM
The estimate for compound 4 lay 1.5-fold (0.18 log units) above the measured number, within the range that was stated.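

In this assay, placing 4-bromophenyl where heptyl stood gives a 1.7-fold lower number from compound 1 to compound 4 (0.23 log units; within the scatter), so on this core the change again stays within what repeated measurements would show. Set side by side, the two steps cannot be told apart, and the change looks alike on both cores as far as this assay can resolve: the same change on two cores in this assay, a 1.1-fold lower number (0.05 log units; within the scatter) from compound 2 to compound 3 and a 1.7-fold lower number (0.23 log units; within the scatter) from compound 1 to compound 4, 1.5-fold (0.18 log units) apart, within the scatter of two such steps. This shows that the change can be carried between these two cores without a step that stands out from the scatter, but it does not show that 4-bromophenyl truly gives a stronger inhibitor than heptyl, nor that the same would hold on a third core.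

The compounds shown cover only heptyl and 4-bromophenyl at this place, so it remains open how a shorter chain, an unsubstituted phenyl or a 4-chlorophenyl would read. On these data alone, it also remains open whether an amine or a carboxylic acid at the end of the chain would move the number beyond the scatter.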